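A few compounds are considered here, and "the series" means these few. Any claim that something is new, unique, unknown or untested is made for them only; others in the source may bear on it.

Measured so far:
compound 1, `CC1CCN(Cc2nc(SCc3ccc(C#N)cc3)[nH]c(=O)c2I)CC1`: > 100000 nM
compound 2, `Cc1cc(C)cc(Cc2nc(SCc3ccc([N+](=O)[O-])cc3)[nH]c(=O)c2I)c1`: 39000 nM

In an ADME assay on HepG2 2.2.15 cells (Homo sapiens) for cytotoxicity, read by MTT assay, with a stated time of 72 h (on this read-out higher numbers stand for lower toxicity in this test and lower numbers for higher toxicity in this test), compound 1 reaches only a limit, > 100000 nM. Going by the values given here, compound 2 gives the only plain number here, 39000 nM; the other result sits at the limit of > 100000 nM in this assay, at which 1 of the 2 values shown sits. Compound 3, `Cc1cc(C)cc(Cc2nc(SCc3ccc(C#N)cc3)[nH]c(=O)c2I)c1`, differs from compound 2 in one place: cyano in place of nitro on an aromatic carbon. Among the compounds with values here, compound 1 already carries the cyano group and in this assay shows only a limit, > 100000 nM, so lower toxicity for compound 3 seems the likelier direction, though no measured step proves it. The expected step from compound 2 to compound 3 is estimated as a 2.1-fold higher number from compound 2 to compound 3 (0.31 log units; beyond the scatter). Compound 3 is expected to give about 80000 nM, between 30000 nM and 200000 nM.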

Compound 3, half-maximal cytotoxic concentration: 43200 nM
For compound 3 the middle estimate is 1.9-fold (0.27 log units) above the measured one; measured number inside the range.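

Cyano in place of nitro gives a 1.1-fold higher number from compound 2 to compound 3 (0.04 log units; within the scatter), so in this assay this position, para to a large group, does not separate the two groups. With cyano held fixed, the other end of the molecule does make a difference: 3,5-dimethylphenyl in place of 4-methylpiperidin-1-yl gives an at least 2.3-fold lower number from compound 1 to compound 3 (0.36 log units; beyond the scatter). The value of compound 1 in that step is a limit, not a number: the limit of > 100000 nM in this assay, at which 1 of the 3 values shown sits.

Still open, from the compounds shown here alone, is whether a different group at this position, such as an amine or a carboxylic acid, would shift the read-out beyond the scatter.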